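The source may report more compounds than this note shows. Statements on the series, on what has been measured and on what is new or still open speak of the compounds shown alone.

Measured so far:
- compound 1 `O=C1C=C(N2CCN(c3ccccc3Cl)CC2)C(=O)c2ccccc21` gives 2900 nM in a functional assay on DU-145 cells (Homo sapiens) for inhibition, read by MTT assay, with a stated time of 72 h; on this read-out lower numbers stand for stronger inhibition and higher numbers for weaker inhibition
- compound 2 `O=C1C=C(N2CCN(c3ccccc3Cl)CC2)C(=O)c2c(O)cccc21` gives 2300 nM in this assay
- compound 3 `Cc1ccccc1C1CCN(C2=CC(=O)c3ccccc3C2=O)CC1` gives 6100 nM in this assay

Compound 1 and compound 2 share one core and differ only by hydroxy in place of hydrogen on an aromatic carbon; this gives a 1.3-fold lower number from compound 1 to compound 2 (0.10 log units; within the scatter), so the two numbers cannot be told apart. Compound 3 carries a different core, and the difference between the two cores is not broken down here. Compound 3 has the highest number of the three, with compound 1 nearest and compound 2 furthest.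

Compound 4 `Cc1ccccc1C1CCN(C2=CC(=O)c3cccc(O)c3C2=O)CC1` is not yet measured. It differs from compound 3 by hydroxy in place of hydrogen on an aromatic carbon, the same change that leads from compound 1 to compound 2, with the same surroundings at the place of the change. On the core of compound 1 that change was flat, so on the core of compound 3 a small step at most is expected in this assay, namely a 1.3-fold lower number from compound 3 to compound 4 (0.10 log units; within the scatter), resting on a 1.3-fold lower number from compound 1 to compound 2 (0.10 log units; within the scatter) and on the value of compound 3 6100 nM. Compound 4 is therefore estimated at 4800 nM, with a likely range from 2500 nM to 9500 nM.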

Compound 4, half-maximal inhibitory concentration: 2500 nM
Estimate against measurement, compound 4: 1.9-fold (0.28 log units) above; the measured number falls inside the stated range.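

In this assay, hydroxy in place of hydrogen on an aromatic carbon gives a 2.4-fold lower number from compound 3 to compound 4 (0.39 log units; beyond the scatter), a modest step on the core of compound 3. Set beside the same change on the core of compound 1, this step cannot be told apart from the earlier one, so the change carries from one core to the other as far as these two pairs can show: the same change on two cores in this assay, a 1.3-fold lower number (0.10 log units; within the scatter) from compound 1 to compound 2 and a 2.4-fold lower number (0.39 log units; beyond the scatter) from compound 3 to compound 4, 1.9-fold (0.29 log units) apart, within the scatter of two such steps. This does not show that the core of compound 3 responds more strongly to the change, even though only its step lies beyond the scatter, and two pairs give no basis for predicting the step on any further core.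

The compounds shown leave open how a methoxy group, an amine or a fluorine atom in place of the hydroxy on the same aromatic carbon would read in this assay. They also leave open whether a step of this size would hold in cell lines other than DU-145.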